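Chlorine for Fluorine on a Benzyl Ring: One Estimate

The source may report more compounds than this note shows. Statements on the series, on what has been measured and on what is new or still open speak of the compounds shown alone.

Compound 1, `O=C(NOCc1ccccc1)c1cn(-c2ccccc2)nc1-c1ccc(Cl)cc1`, gives 10800 nM in a functional assay on MCF7 cells (Homo sapiens) for antiproliferative activity, read by MTT assay, with a stated time of 48 h, in the presence of a further agent that is not named here; a lower number here means a stronger inhibitor of growth, a higher number a weaker inhibitor of growth.
Compound 2, `O=C(NOCc1ccccc1)c1cn(-c2ccccc2)nc1-c1ccc(F)cc1`, gives 15300 nM in this assay.
Compound 3, `O=C(NOCc1ccccc1F)c1cn(-c2ccccc2)nc1-c1ccc(F)cc1`, gives 12000 nM in this assay.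

Compound 4, `O=C(NOCc1ccccc1Cl)c1cn(-c2ccccc2)nc1-c1ccc(F)cc1`, has not been measured. It differs from compound 3 by chloro in place of fluoro on an aromatic carbon. The same change, taken from compound 2 to compound 1, is chloro in place of fluoro on an aromatic carbon, and it gave a 1.4-fold lower number from compound 2 to compound 1 (0.15 log units; within the scatter). The two cores differ by fluoro in place of hydrogen on an aromatic carbon, with a step of a 1.3-fold lower number from compound 2 to compound 3 (0.11 log units; within the scatter). The place is not the same: in compound 1 the chloro sits para to a large group, in compound 4 ortho to a large group, so this is the same kind of change rather than the same change. Because the earlier step was a 1.4-fold lower number from compound 2 to compound 1 (0.15 log units; within the scatter), a step of similar size, a 1.3-fold lower number from compound 3 to compound 4 (0.10 log units; within the scatter), is expected here. Compound 4 is therefore estimated at 9500 nM, likely between 5000 nM and 18000 nM.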

Compound 4, concentration for 50% growth inhibition: 11400 nM
Compound 4: the middle estimate sits 1.2-fold (0.08 log units) below what was measured, within the range that was stated.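

In this assay, going from 2-fluorobenzyl to 2-chlorobenzyl gives a 1.1-fold lower number from compound 3 to compound 4 (0.02 log units; within the scatter), and chloro in place of hydrogen on that ring gives a 1.3-fold lower number from compound 2 to compound 4 (0.13 log units; within the scatter). Set beside the earlier swap of fluoro for chloro, the change looks alike on the two cores: the same change on two cores in this assay, a 1.4-fold lower number (0.15 log units; within the scatter) from compound 2 to compound 1 and a 1.1-fold lower number (0.02 log units; within the scatter) from compound 3 to compound 4, 1.3-fold (0.13 log units) apart, within the scatter of two such steps

This gives no sign that the core alters the change, but it does not prove that the change carries over, since every step is within the scatter and the chloro sits in a different place in the two pairs. The compounds shown leave open whether a different group on the benzyl ring, such as an amine or a carboxylic acid, would give a step beyond the scatter.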